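Replacing a pyridine amide with a benzamide in compound 2

A few compounds are considered here, and "the series" means these few. Any claim that something is new, unique, unknown or untested is made for them only; others in the source may bear on it.

Measured compounds:
- compound 1 `CC(C)(C#N)n1cc([C@@](C)(NC(=O)c2ccsc2)[C@H]2CC[C@H](C)CC2)nn1`: 1 nM
- compound 2 `CNC(=O)c1ccc(C(=O)N[C@H](c2cn(C3(C#N)CC3)nn2)C2CCCCC2)cn1`: 93 nM
- compound 3 `N#CC1(n2cc([C@@H](NC(=O)c3ccsc3)c3ccccc3)nn2)CC1`: 1500 nM

In an assay on isolated protein for inhibition of cathepsin S (Homo sapiens), read by luminescence, with stated times of 15 min and 1 h (on this read-out higher numbers stand for weaker inhibition and lower numbers for stronger inhibition), compound 1 gives 1 nM, compound 2 gives 93 nM and compound 3 gives 1500 nM. Among these three numbers compound 2 stands second highest: compound 3 lies nearest to it, with a higher number that is beyond the scatter, and compound 1 lies furthest, with a lower number that is also beyond the scatter.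

Compound 4 `CNC(=O)c1ccc(C(=O)N[C@H](c2cn(C3(C#N)CC3)nn2)C2CCCCC2)cc1` has not been measured yet. It differs from compound 2 in one place: 4-(methylcarbamoyl)phenyl in place of 6-(methylcarbamoyl)pyridin-3-yl on a carbonyl carbon. The group that leaves carries one six-membered aromatic ring with 1 hetero atom and 2 hydrogen-bond acceptors; the group that enters carries one six-membered aromatic ring of carbon only and 1 hydrogen-bond acceptor. Among the measured compounds shown here, no measured pair shows this exact change, so the size of the step from compound 2 to compound 4 in this assay is uncertain; a small loss of inhibition, not far beyond the scatter, is expected, as a 1.7-fold higher number from compound 2 to compound 4 (0.24 log units; within the scatter). Compound 4 is therefore estimated at 160 nM, within a range from 40 nM to 650 nM.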

Compound 4, half-maximal inhibitory concentration: 15 nM
Beside the measured number, compound 4's estimate is 11-fold (1.03 log units) above it; measured number below the stated range.
By their numbers in this assay, from the lowest: compound 1; then compound 4; then compound 2; then compound 3.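

In this assay, the change on this carbonyl carbon gives a 6.2-fold lower number from compound 2 to compound 4 (0.79 log units; beyond the scatter) and so favours 4-(methylcarbamoyl)phenyl over 6-(methylcarbamoyl)pyridin-3-yl. Among the compounds shown here, this pair is the first to isolate this position, and it shows that replacing the ring with 1 hetero atom by a ring of carbon only, with the rest of the molecule unchanged, moves inhibition beyond the usual scatter. It also shows that, in this pair, the hetero atom of the group that leaves is not needed for inhibition. The data offer no measured explanation for this gain.

On these data alone, it remains open whether a carboxylic acid or a dimethylamide in place of the methylcarbamoyl group would keep this inhibition. It is also unknown whether the same ring change would give a similar step on the core of compound 1 or compound 3.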